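The source may report more compounds than this note shows. Statements on the series, on what has been measured and on what is new or still open speak of the compounds shown alone.

Measured so far:
compound 1 `N#Cc1ccc(N2CCc3cc(-c4cncnc4)ccc32)cc1C(F)(F)F` — "not determined" (no result reported) in a functional assay on VCaP cells (Homo sapiens) for antiproliferative activity, read by CCK-8 assay, with a stated time of 6 days; on this read-out higher numbers stand for weaker inhibition and lower numbers for stronger inhibition
compound 2 `CCN(c1ccc(C#N)c(Cl)c1)c1cc(-c2ccccc2)ccc1C` — > 30000 nM (a limit)

Compound 1 `N#Cc1ccc(N2CCc3cc(-c4cncnc4)ccc32)cc1C(F)(F)F` carries no result in this assay; its entry reads "not determined" (no result reported). Compound 2 `CCN(c1ccc(C#N)c(Cl)c1)c1cc(-c2ccccc2)ccc1C` reaches only the limit of this assay, > 30000 nM, and this is a limit, not a number. Compound 2 therefore stands at the upper edge of what this assay reports, as the limit of > 30000 nM in this assay, at which 1 of the 2 values shown sits, states for one of the two entries shown, with the other entry holding no number at all.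

Compound 3 `CCN(c1ccc(C#N)c(Cl)c1)c1cc(-c2ccc(F)nc2)ccc1C` differs from compound 2 in one place: 6-fluoropyridin-3-yl in place of phenyl on an aromatic carbon. Within the data shown here, no measured step of this kind is available. The step from compound 2 to compound 3 is expected to be small, if anything toward lower numbers, and most likely not to carry compound 3 clearly off the limit. Compound 3 is estimated at 20000 nM, within 5000 nM to 30000 nM, which means an expected step of an at least 1.5-fold lower number from compound 2 to compound 3 (0.17 log units; that floor lies within the scatter).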

Compound 3, half-maximal inhibitory concentration: > 30000 nM
Compound 3: no number, only a limit; the forecaster's own chance of this, stated with the estimate: 60%; middle value at least 1.5-fold (0.17 log units) from the limit.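

No step can be read between compound 2 and compound 3 in this assay, with both entries only limits: the limit of > 30000 nM in this assay, at which 2 of the 3 values shown sit.

The compounds shown leave open whether 6-fluoropyridin-3-yl in place of phenyl on an aromatic carbon shifts the value at all, and what number either compound would give.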